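The source may report more compounds than this note shows. Statements on the series, on what has been measured and on what is new or still open speak of the compounds shown alone.

Compound 1 `COOC1(OOC)CCCCCCCCCCC1` stands lowest of the two measured compounds. In a functional assay on FM3A cells (Mus musculus) for cytotoxicity (on this read-out higher numbers stand for an effect only at larger amounts of compound and lower numbers for an effect already at smaller amounts), compound 1 gives 1500 nM, while compound 2 `C=CCOOC1(OOCC=C)CCCCCCCCCCC1` gives 14000 nM, a gap beyond the usual scatter. Compound 3 `COOC1(OOCCCCCCI)CCCCCCCCCCC1` has not been measured yet. It keeps the core of compound 1 and alters one end: 5-iodopentyl in place of hydrogen on a saturated chain carbon bound to an oxygen. Among the measured compounds shown here, no measured pair shows this change alone, so the forecast is uncertain. For the measured compounds named here, the only hint is that compound 2, at 14000 nM, carries a different pair of end groups and has a higher number than compound 1, so a moderate rise is expected here too, probably beyond the scatter. The expected change is a 2.7-fold higher number from compound 1 to compound 3 (0.43 log units; beyond the scatter). For compound 3 the estimated value is 4000 nM, within an expected range of 900 nM to 18000 nM.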

Compound 3, half-maximal effective concentration: 86000 nM
Compound 3: the middle estimate sits 22-fold (1.33 log units) below what was measured, and the stated range ends below it.
By their numbers in this assay, from the lowest: compound 1; then compound 2; then compound 3.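

In this assay, among the compounds shown here, this is the first reading of this position on its own: 5-iodopentyl in place of hydrogen on a saturated chain carbon bound to an oxygen gives a 57-fold higher number from compound 1 to compound 3 (1.76 log units; beyond the scatter), a large step. It shows that this end of the molecule matters: changing one end, while the shared core and the other end stay as they are, is enough to move the number far beyond the scatter. Nothing available here explains why the number moves so much.

The compounds shown do not separate the part played by the chain length from that of the iodine at its end. A plain hexyl group, a shorter iodoalkyl chain, or a chain ending in an amine in the same place would each help to tell these apart.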